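The compounds below may be only part of what the source reports. "The series", "measured", "known", "first", "only" and "open" are said of these compounds alone.

Working notes on the series. The shared core of compound 1, `O=C(c1cccc(Cl)c1)N1CCC(NS(=O)(=O)c2cc(S(=O)(=O)c3ccccc3)ccc2C(F)(F)F)CC1`, carries a 3-chlorophenyl group on the amide carbonyl carbon; in a physicochemical assay for solubility (on this read-out lower numbers stand for lower solubility and higher numbers for higher solubility), compound 1 gives 6300 nM. Two other members have been measured in this assay. Compound 2, `O=S(=O)(NC1CCN(S(=O)(=O)c2cccc(-c3nnn[nH]3)c2)CC1)c1cc(S(=O)(=O)c2ccccc2)ccc1C(F)(F)F`, gives 100000 nM, and compound 3, `CC(C)(C)OC(=O)N1CCC(C(=O)N2CCC(NS(=O)(=O)c3cc(S(=O)(=O)c4ccccc4)ccc3C(F)(F)F)CC2)CC1`, gives 25000 nM. Compound 1 thus stands lowest of the three numbers, with compound 3 nearest and compound 2 furthest, and both gaps lie beyond the usual scatter.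

The next step is to compound 4, `CC(C)(C)OC(=O)N1CCC[C@@H]1C(=O)N1CCC(NS(=O)(=O)c2cc(S(=O)(=O)c3ccccc3)ccc2C(F)(F)F)CC1`, which is not yet measured in this assay. It differs from compound 1 in one place: 1-(tert-butoxycarbonyl)pyrrolidin-2-yl in place of 3-chlorophenyl on a carbonyl carbon. Within the data shown here, no step between measured compounds covers this exact change, so the expectation rests on what the three values show. The other member that differs from compound 1 at this carbonyl carbon is compound 3, which gives 25000 nM, a number that sits well above that of compound 1.

On that basis the step from compound 1 to compound 4 is expected to go upward and to exceed the scatter, at a 3.2-fold higher number from compound 1 to compound 4 (0.50 log units; beyond the scatter). Compound 4 is accordingly estimated at 20000 nM, with a range from 6000 nM to 60000 nM.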

Compound 4, solubility: 25000 nM
The estimate for compound 4 lay 1.3-fold (0.10 log units) below the measured number; the measured number falls inside the stated range.
By their numbers in this assay, from the lowest: compound 1; then compounds 3 and 4 (each within the scatter of the next); then compound 2.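

In this assay, among these compounds, the step of a 4.0-fold higher number from compound 1 to compound 4 (0.60 log units; beyond the scatter) is the first reading of a single change at this carbonyl carbon, and it lies beyond the scatter: 1-(tert-butoxycarbonyl)pyrrolidin-2-yl replaces 3-chlorophenyl, so a five-membered non-aromatic ring with a defined stereocentre stands where a chlorinated six-membered aromatic ring stood. Compound 4 gives 25000 nM and compound 3, which also carries a tert-butoxycarbonyl group, gives 25000 nM in the same read-out, so these two values sit within the scatter of each other and both stand apart from the number of compound 1. This single step cannot separate the contributions of the ring, the tert-butoxycarbonyl group and the stereocentre, and no supporting data bear on the origin of the shift.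

Still open, from the compounds shown here alone, is how the number responds when the pyrrolidine nitrogen is a free amine, without its tert-butoxycarbonyl group, or when the stereocentre is inverted. Equally open, going by these compounds, is where a carboxylic acid or a plain alkyl chain on this carbonyl carbon would fall relative to compound 4.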